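A few compounds are considered here, and "the series" means these few. Any claim that something is new, unique, unknown or untested is made for them only; others in the source may bear on it.

Measured compounds in a functional assay (muscle tissue) with Cavia porcellus as the target; a higher number here means that more compound is needed for the effect, a lower number that less compound is needed:

compound 1 `C=Cc1ccccc1C1C(C(=O)OC)=C(C)N=C(C)/C1=C(\O)OC`: 4.47 nM
compound 2 `COC(=O)C1=C(C)N=C(C)/C(=C(\O)OC)C1c1cc(Cl)cc(Cl)c1`: 93.3 nM
compound 3 `COC(=O)C1=C(C)N=C(C)/C(=C(\O)OC)C1c1cccc(C#N)c1`: 34.7 nM

Compound 3 stands second of the three numbers in this assay: compound 1 needs less compound, with the step of a 7.8-fold higher number from compound 1 to compound 3 (0.89 log units; beyond the scatter), and compound 2 needs more, with the step of a 2.7-fold lower number from compound 2 to compound 3 (0.43 log units; beyond the scatter). The widest spread in the set is a 21-fold higher number from compound 1 to compound 2 (1.32 log units; beyond the scatter), so the aryl group on the saturated ring carbon moves the read-out over a large span.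

Compound 4 `COC(=O)C1=C(C)N=C(C)/C(=C(\O)OC)C1c1ccc(Br)cc1` differs from compound 3 as follows: 4-bromophenyl in place of 3-cyanophenyl on a saturated ring carbon.

Among the compounds with values here, no measured step replaces a 3-cyanophenyl with a 4-bromophenyl, so the expectation rests on the three steps above, which only show that the halogen-bearing ring of compound 2 gives a higher number than compound 3. A modest rise in the number beyond the scatter is therefore expected for compound 4, as a 4.3-fold higher number from compound 3 to compound 4 (0.64 log units; beyond the scatter). The value of compound 4 in this assay is estimated at 150 nM, with a range from 40 nM to 600 nM.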

Compound 4, half-maximal effective concentration: 540 nM
Compound 4: middle estimate off by 3.6-fold (0.56 log units), on the low side; the measured number falls inside the stated range.
By their numbers in this assay, from the lowest: compound 1; then compound 3; then compound 2; then compound 4.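

In this assay, 4-bromophenyl on the saturated ring carbon gives the highest number of the four aryl groups, above 3-cyanophenyl (a 16-fold higher number from compound 3 to compound 4 (1.19 log units; beyond the scatter)). A halogen on the aryl ring does not by itself fix the number, as the two halogen-bearing compounds still differ (a 5.8-fold higher number from compound 2 to compound 4 (0.76 log units; beyond the scatter)), and the span at this position is now at its widest (a 120-fold higher number from compound 1 to compound 4 (2.08 log units; beyond the scatter)). No measurement at hand accounts for these differences.

On these data alone, the step from 3-cyanophenyl to 4-bromophenyl changes both the substituent and its place on the aryl ring, so the share of each remains open; 3-bromophenyl and 4-cyanophenyl would separate the two. As far as these compounds go, whether the low number of compound 1 belongs to the vinyl group or to its place on the ring also remains open, and 2-bromophenyl would bear on that.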